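Swapping an acetyl for a piperazine on the aryl ring

A few compounds are considered here, and "the series" means these few. Any claim that something is new, unique, unknown or untested is made for them only; others in the source may bear on it.

Two measured compounds set the scene. Compound 1 `CNc1nc(NCCCN(C)C)c2sc(-c3ccc(N)cc3)cc2n1` carries an amino group on its outer aromatic ring, and in a physicochemical assay for solubility, in phosphate buffer, at pH 6.5 (a lower number here means a less soluble compound, a higher number a more soluble compound), compound 1 gives 12.5 ug/mL. Compound 2 `CNc1nc(NCCCN(C)C)c2sc(-c3ccc(C(C)=O)cc3)cc2n1` carries an acetyl group instead, and in this assay compound 2 gives 12.5 ug/mL. The step of no change at the digits printed from compound 1 to compound 2 (within the scatter) shows that this exchange left the read-out where it was. So compound 2 stands level with compound 1, with nothing in the measured data to separate the two.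

Compound 3 `CNc1nc(NCCCN(C)C)c2sc(-c3ccc(N4CCNCC4)cc3)cc2n1` is the unmeasured one. Compared with compound 2 it differs in one place: piperazin-1-yl in place of acetyl on an aromatic carbon. Among the measured compounds shown here, the only measured step that touches this position, from compound 1 to compound 2, moved nothing beyond the scatter, so there is no measured precedent for a group of this kind entering here. The change is nevertheless larger than the earlier one, adding a ring and a hydrogen-bond donor. A rise in this assay is expected, yet with little certainty, and the step of a 3.2-fold higher number from compound 2 to compound 3 (0.51 log units; beyond the scatter) is an estimate. For compound 3 a value of 40 ug/mL is expected, within a range from 10 ug/mL to 160 ug/mL.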

Compound 3, solubility: 12.5 ug/mL
Compound 3: middle estimate off by 3.2-fold (0.51 log units), on the high side; the range from low to high includes it.
By their numbers in this assay, from the lowest: compounds 1, 2 and 3 (each within the scatter of the next).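

In this assay the exchange of acetyl for piperazin-1-yl brings no change at the digits printed from compound 2 to compound 3 (within the scatter) and the exchange of amino for piperazin-1-yl brings no change at the digits printed from compound 1 to compound 3 (within the scatter) so all three groups now stand level at this place. The earlier pair covered only amino and acetyl, whereas this result adds a group of 6 heavy atoms with a six-membered non-aromatic ring and a hydrogen-bond donor, and even a change of that size on an aromatic carbon para to a large group leaves the read-out where it was. Nothing at hand accounts for this sameness, so it stands as an observation without an explanation.

These three compounds cannot tell whether any group at this place would move the number, for instance a carboxylic acid, a morpholine ring or a longer chain ending in an amine. They also leave open whether the same exchanges would give the same flat result on a core with a different side chain, since all three compounds share one core and differ only in this single group.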